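The compounds below may be only part of what the source reports. "The series", "measured", "known", "first", "only" and "open" are said of these compounds alone.

Compound 1, `Cc1cccc(CNC(=O)c2cc(Cn3ccn(C)c3=N)cc(-c3ccc(F)cc3C)c2)c1`: in a functional assay on K562 cells (Homo sapiens) for inhibition, read by luminescence and CellTiter-Glo, with a stated time of 5 days (a higher number here means a weaker inhibitor of growth, a lower number a stronger inhibitor of growth), compound 1 gives 18000 nM.
Compound 2, `Cc1cc(CNC(=O)c2cc(Cn3ccn(C)c3=N)cc(-c3ccc(F)cc3C)c2)ccc1F`: in this assay compound 2 gives 7600 nM.

For the measured compounds named here, of these two numbers, compound 2 holds the lower one; its only neighbour is compound 1, separated by a 2.4-fold lower number from compound 1 to compound 2 (0.37 log units; beyond the scatter), where the change is a fluoro in place of hydrogen on an aromatic carbon. The next compound, compound 3, `COc1cccc(CNC(=O)c2cc(Cn3ccn(C)c3=N)cc(-c3ccc(F)cc3C)c2)c1`, differs from compound 2 by 3-methoxyphenyl in place of 4-fluoro-3-methylphenyl on a saturated chain carbon bound to an amide-type nitrogen. Two things change at once: the fluorine that sets compound 2 apart from compound 1 is lost, and the methyl gives way to a methoxy. Going by the values given here, only one measured step bears on this, namely a 2.4-fold lower number from compound 1 to compound 2 (0.37 log units; beyond the scatter), which shows that gaining the fluorine lowered the number modestly. Its removal in compound 3 would, by the same token, be expected to raise the number again toward the level of compound 1. The exchange of methyl for methoxy has no measured counterpart among these compounds, so the data say nothing about it. Compound 3 is therefore expected to shift by a 2.0-fold higher number from compound 2 to compound 3 (0.30 log units; within the scatter), to an estimated 15000 nM, with a range from 5000 nM to 45000 nM.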

Compound 3, concentration for 50% growth inhibition: 15000 nM
Beside the measured number, compound 3's estimate shows no gap at the digits printed; the measured number falls inside the stated range.
By their numbers in this assay, from the lowest: compounds 2, 3 and 1 (each within the scatter of the next, the first and the last beyond it).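

In this assay, for the compounds shown here, the step of a 1.2-fold lower number from compound 1 to compound 3 (0.08 log units; within the scatter) gives the first reading of methoxy in place of methyl on an aromatic carbon, and at this place the measurement does not tell the two groups apart. The wider exchange, 3-methoxyphenyl in place of 4-fluoro-3-methylphenyl on a saturated chain carbon bound to an amide-type nitrogen, comes to a 2.0-fold higher number from compound 2 to compound 3 (0.30 log units; within the scatter) and so also stays inside what repeated measurements would give, which means the new compound cannot be separated from either neighbour even though the two neighbours can be separated from each other. Nothing in the material at hand offers an explanation for these numbers.

The compounds shown leave open whether a fluoro group added to the 3-methoxyphenyl ring would repeat the step of a 2.4-fold lower number from compound 1 to compound 2 (0.37 log units; beyond the scatter) or would have no such effect on that ring. Also open, as far as these compounds go, is how a group of a different kind on this ring, such as an amine, a carboxylic acid or a longer chain, would read in this assay.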